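The compounds below may be only part of what the source reports. "The series", "measured", "known", "first", "only" and "open" are said of these compounds alone.

Working notes on the nitroimidazole–oxadiazole series in a functional assay on MCF7 cells (Homo sapiens) for cytotoxicity, read by MTT assay, with a stated time of 48 h; on this read-out lower numbers stand for stronger inhibition and higher numbers for weaker inhibition. Compound 1 `Cc1ccccc1-c1nnc(SCCn2c([N+](=O)[O-])cnc2C)o1` gives 15800 nM. Compound 2 `Cc1ncc([N+](=O)[O-])n1CCSc1nnc(-c2ccccc2Cl)o1` gives 22500 nM, and compound 3 `Cc1ncc([N+](=O)[O-])n1CCSc1nnc(-c2ccc(Cl)cc2)o1` gives 18700 nM. Compound 3 holds the second highest of the three numbers; its nearest neighbour is compound 1 with a 1.2-fold higher number from compound 1 to compound 3 (0.07 log units; within the scatter), its furthest compound 2 with a 1.2-fold lower number from compound 2 to compound 3 (0.08 log units; within the scatter), so all three sit within the scatter of one another.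

The next compound, compound 4 `Cc1ncc([N+](=O)[O-])n1CCSc1nnc(-c2ccncc2)o1`, differs from compound 3 by pyridin-4-yl in place of 4-chlorophenyl on an aromatic carbon. Every measured step alters the aryl group on the shared core: a 1.4-fold higher number from compound 1 to compound 2 (0.15 log units; within the scatter), a 1.2-fold higher number from compound 1 to compound 3 (0.07 log units; within the scatter) and a 1.2-fold lower number from compound 2 to compound 3 (0.08 log units; within the scatter) were all within the scatter. Among the compounds with values here, none of them exchanges a carbon of that ring for a ring nitrogen, so the pyridin-4-yl change has no direct precedent here, but the aryl position has so far tolerated change without a step beyond the scatter.

Compound 4 is therefore estimated at 20000 nM, with a range of 8000 nM to 50000 nM. The expected step of a 1.1-fold higher number from compound 3 to compound 4 (0.03 log units; within the scatter) is expected to stay within the scatter, in no firm direction.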

Compound 4, half-maximal inhibitory concentration: 12600 nM
For compound 4 the middle estimate is 1.6-fold (0.20 log units) above the measured one; measured number inside the range.
By their numbers in this assay, from the lowest: compounds 4, 1, 3 and 2 (each within the scatter of the next).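

In this assay the steps of a 1.5-fold lower number from compound 3 to compound 4 (0.17 log units; within the scatter) and a 1.8-fold lower number from compound 2 to compound 4 (0.25 log units; within the scatter) and a 1.3-fold lower number from compound 1 to compound 4 (0.10 log units; within the scatter) all lie within the scatter, so this position shows no measurable response to the exchange. The earlier compounds shown here carried only aromatic rings of carbon here, whereas pyridin-4-yl brings a ring with a hetero atom and a hydrogen-bond acceptor, and the four compounds still cannot be told apart. No supporting data bear on this result.

Still open, on these data alone, is whether pyridin-2-yl, pyridin-3-yl, an aminophenyl group or a benzoic acid group at this position would give a step beyond the scatter. The compounds shown also leave open whether a longer chain on the shared core would do so, since every step here alters the aryl group alone.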